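The source may report more compounds than this note shows. Statements on the series, on what has been measured and on what is new or still open speak of the compounds shown alone.

Going by the values given here, in a functional assay (microsomes, liver) with Rattus norvegicus as the target (on this read-out higher numbers stand for weaker inhibition and lower numbers for stronger inhibition), compound 1 `Cc1c(C)c2c(c(C)c1N)CC(C)(CSc1ccncc1)O2` gives 630 nM, the higher of the two numbers measured so far. Compound 2 `Cc1c(C)c2c(c(C)c1N)CC(C)(CSCc1ccccc1)O2` gives 260 nM. Compound 3 `Cc1c(C)c2c(c(C)c1N)CC(C)(CNc1ccccc1)O2` differs from compound 1 at a single place, anilino in place of (pyridin-4-yl)sulfanyl on a saturated chain carbon bound to a saturated ring carbon. Among the compounds with values here, only one measured step bears on this change: a 2.4-fold lower number from compound 1 to compound 2 (0.38 log units; beyond the scatter), a modest move beyond the scatter, with benzyl in place of pyridin-4-yl on a sulfur. Like compound 2, compound 3 carries a six-membered aromatic ring of carbon only, but it also loses the sulfur, and no measured step tests that loss. A similar modest move to a lower number is therefore expected in this assay, an estimated 2.1-fold lower number from compound 1 to compound 3 (0.32 log units; beyond the scatter). Compound 3 is estimated at 300 nM, with an expected range from 100 nM to 900 nM.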

Compound 3, half-maximal inhibitory concentration: 260 nM
Compound 3: the middle estimate sits 1.2-fold (0.06 log units) above what was measured; the measured number falls inside the stated range.
By their numbers in this assay, from the lowest: compounds 2 and 3 (each within the scatter of the next); then compound 1.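

In this assay, putting anilino in place of (pyridin-4-yl)sulfanyl gives a 2.4-fold lower number from compound 1 to compound 3 (0.38 log units; beyond the scatter) on the saturated chain carbon bound to a saturated ring carbon. The earlier compounds shown here all carried sulfur at this place, whereas compound 3 has none and still lies within the scatter of compound 2, so a lower number here does not depend on sulfur. Nothing measured alongside these numbers accounts for the step.

The change replaces the sulfur link and the pyridine ring together, so the compounds shown cannot assign the step to either one alone; phenylsulfanyl and (pyridin-4-yl)amino would separate the two. Also open, on these data alone, is how phenoxy, with an oxygen link, or an N-methylanilino group would read at the same place.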